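Halogen Swap on the Amide Arm of a Shared Core

A few compounds are considered here, and "the series" means these few. Any claim that something is new, unique, unknown or untested is made for them only; others in the source may bear on it.

The measured compounds and their values in a functional assay on HepG2 cells (Homo sapiens) for antiproliferative activity, read by CCK-8 assay, with a stated time of 72 h; a lower number here means a stronger inhibitor, a higher number a weaker inhibitor:

Compound 1, `O=C(Nc1cccc(-c2oc3cc(-c4ccc(F)cc4)ccc3c(=O)c2O)c1)c1ccc(F)cc1`, gives 9280 nM.
Compound 2, `O=C(Nc1cccc(-c2oc3cc(-c4ccc(F)cc4)ccc3c(=O)c2O)c1)c1ccc(Cl)cc1`, gives 11000 nM.
Compound 3, `O=C(Nc1cccc(-c2oc3cc(-c4ccc(F)cc4)ccc3c(=O)c2O)c1)c1ccc(F)cc1F`, gives 26400 nM.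

Compound 3 stands at the highest number of the three, that is, as the weakest inhibitor among them: its value lies beyond the scatter from both others, with compound 2 the nearer and compound 1 the further of the two. The unmeasured compound 4, `O=C(Nc1cccc(-c2oc3cc(-c4ccc(F)cc4)ccc3c(=O)c2O)c1)c1ccc(Br)cc1`, differs from compound 3 in one place: 4-bromophenyl in place of 2,4-difluorophenyl on a carbonyl carbon.

Among the measured compounds shown here, two measured steps bear on this change. First, a 2.8-fold higher number from compound 1 to compound 3 (0.45 log units; beyond the scatter); undoing that extra fluoro should therefore bring the number back down by about that amount. Second, a 1.2-fold higher number from compound 1 to compound 2 (0.07 log units; within the scatter), so exchanging one halogen for another in the same spot did little, and bromo is taken here to behave like chloro. Taken together, the expectation is a 2.2-fold lower number from compound 3 to compound 4 (0.34 log units; beyond the scatter), landing compound 4 near compound 2 and compound 1.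

Compound 4 is thus estimated at 12000 nM in this assay, with a range from 6000 nM to 24000 nM.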

Compound 4, half-maximal inhibitory concentration: 13900 nM
Compound 4: middle estimate off by 1.2-fold (0.06 log units), on the low side, within the range that was stated.
By their numbers in this assay, from the lowest: compounds 1, 2, 4 and 3 (each within the scatter of the next, the first and the last beyond it).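

In this assay, 4-bromophenyl in place of 2,4-difluorophenyl on the carbonyl carbon gives a 1.9-fold lower number from compound 3 to compound 4 (0.28 log units; within the scatter), so compound 3, which stands clearly apart from compound 1 and compound 2, does not stand clearly apart from compound 4. Bromo in place of chloro gives a 1.3-fold higher number from compound 2 to compound 4 (0.10 log units; within the scatter) and bromo in place of fluoro gives a 1.5-fold higher number from compound 1 to compound 4 (0.18 log units; within the scatter), which adds a third halogen to the series and shows that compound 1, compound 2 and compound 4 cannot be told apart in this measurement, whichever of the three halogens the ring carries. The data shown hold no independent measurement that could explain these results.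

Every group shown at this place is a phenyl ring carrying halogen, so it remains open whether a methoxy group, an amine or a carboxylic acid on that ring would move the number beyond the scatter. From the compounds shown here alone, it is also open whether a 2,4-dichlorophenyl group would give a number like that of compound 3 or like those of the singly halogenated compounds.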